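Methylsulfanyl for chloro on a fused core: an expectation

The source may hold more compounds than are shown below. What is called first, only, known or untested is meant among the compounds shown, and "the series" means these compounds.

Of the compounds shown here, three have been measured in a functional assay on the whole organism (strain L.) for inhibition, with Echinochloa crus-galli as the target, with a stated time of 72 h, tested at 100 mg/L; a higher number here means more inhibition of growth at the concentration tested, a lower number less inhibition of growth. Compound 1 `COc1cc(SC)nc(NC(=S)NC(=O)c2c(-c3ccc(Cl)cc3Cl)noc2C)n1` gives 40.9%, compound 2 `COc1cc(Cl)nc(NC(=S)NC(=O)c2c(-c3ccc(Cl)cc3Cl)noc2C)n1` gives 56.3%, and compound 3 `COc1cc(Cl)nc2n/c(=N/C(=O)c3c(-c4ccc(Cl)cc4Cl)noc3C)sn12` gives 40.8%. The values of compound 1 and compound 3 lie within the scatter of each other. Compound 2 and compound 1 differ in one place, (methylsulfanyl in place of chloro on an aromatic carbon), and this step made a number 15.4 percentage points lower from compound 2 to compound 1 (beyond the scatter). How the core of compound 3 differs from the core of compound 2 is not broken down here.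

Compound 4 `COc1cc(SC)nc2n/c(=N/C(=O)c3c(-c4ccc(Cl)cc4Cl)noc3C)sn12` has not yet been measured. It differs from compound 3 by methylsulfanyl in place of chloro on an aromatic carbon, the same kind of change as from compound 2 to compound 1, but here the ring carries the change as part of a fused or bridged system of two rings, meta and para to a fused ring, where in compound 1 it stands meta to a large group. For compound 4 in this assay a step of about a number 13.8 percentage points lower from compound 3 to compound 4 (beyond the scatter) is expected, resting on compound 2 giving 56.3% and compound 1 giving 40.9%. Compound 4 is thus estimated at 27%, between 10% and 44%.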

Compound 4, percent growth inhibition at one concentration: 55.6%
Compound 4: the middle estimate sits 28.6 percentage points below what was measured; the measured number lies above the stated range.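

Moved to the second core, methylsulfanyl in place of chloro makes a number 14.8 percentage points higher from compound 3 to compound 4 (beyond the scatter) in this assay. The same change therefore does not bring a fixed effect from one core to the other in this series, and even its direction reverses: the same change on two cores in this assay, a number 15.4 percentage points lower (beyond the scatter) from compound 2 to compound 1 and a number 14.8 percentage points higher (beyond the scatter) from compound 3 to compound 4, 30.2 percentage points apart, beyond the scatter of two such steps

Going by these compounds alone, these are only two matched pairs, each read at a single concentration in one organism, so they do not show why the direction reverses or how the change would behave on any third core.

Still open, as far as these compounds go, is whether an amine or a longer chain such as butylsulfanyl in the same place would also give opposite steps on the two cores, which would show whether the reversal is peculiar to methylsulfanyl. Also open, from the compounds shown here alone, is whether the reversal would persist at other concentrations, since a single reading cannot show how growth inhibition follows the dose.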